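Urea to benzamide at the carbonyl of the pyrazole series

This account rests on a few compounds, and the source may have more. Where it says the series, first, only, none or still open, it means among the compounds named here.

Among the compounds with values here, compound 3 `COc1cc(-c2nn(-c3cccc(NC(=O)Nc4cccc(C(F)(F)F)c4)c3)cc2-c2ccncc2)ccc1Cl` gives 1400 nM in a functional assay on SN12C cells (Homo sapiens) for inhibition, read by sulforhodamine B assay, with a stated time of 48 h (a higher number here means a weaker inhibitor of growth, a lower number a stronger inhibitor of growth), the lowest of the three numbers so far, though both neighbours lie within the scatter of it: compound 1 `O=C(Nc1cccc(-n2cc(-c3ccncc3)c(-c3ccc(Cl)c(O)c3)n2)c1)Nc1cccc(C(F)(F)F)c1` gives 2010 nM and compound 2 `COc1cc(-c2nn(-c3cccc(NC(=O)Nc4ccc(Cl)c(Cl)c4)c3)cc2-c2ccncc2)ccc1Cl` gives 1470 nM. The steps of a 1.4-fold lower number from compound 1 to compound 3 (0.16 log units; within the scatter) and a 1.1-fold lower number from compound 2 to compound 3 (0.02 log units; within the scatter) are both small. Compound 4 `COc1cc(-c2nn(-c3cccc(NC(=O)c4ccccc4)c3)cc2-c2ccncc2)ccc1Cl` carries the change (phenyl in place of (3-(trifluoromethyl)phenyl)amino on a carbonyl carbon), so the carbonyl carbon then bears phenyl directly. Within the data shown here, the only measured step touching the group on the amide-type nitrogen, a 1.1-fold lower number from compound 2 to compound 3 (0.02 log units; within the scatter), swaps one aryl for another and leaves this assay essentially unchanged; no measured step removes the amino link itself. A step of a 2.3-fold higher number from compound 3 to compound 4 (0.36 log units; beyond the scatter) toward a higher number is expected, with wide uncertainty. Compound 4 is therefore estimated at 3200 nM, range 1000 nM to 10000 nM.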

Compound 4, concentration for 50% growth inhibition: 2950 nM
Beside the measured number, compound 4's estimate is 1.1-fold (0.04 log units) above it, within the range that was stated.
By their numbers in this assay, from the lowest: compounds 3, 2, 1 and 4 (each within the scatter of the next, the first and the last beyond it).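

Phenyl in place of (3-(trifluoromethyl)phenyl)amino on the carbonyl carbon gives the only step in this series beyond the scatter, a 2.1-fold higher number from compound 3 to compound 4 (0.32 log units; beyond the scatter) in this assay for a modest shift. Against the dichlorophenyl urea the same change stays within the scatter, a 2.0-fold higher number from compound 2 to compound 4 (0.30 log units; within the scatter) on the printed values, so the effect of this change is small and depends on the comparison. Nothing measured here explains the step.

Compound 4 lacks both the amino link and the trifluoromethyl group, and these two changes cannot be separated. On these data alone, how a benzyl group or a piperazine on the carbonyl carbon would read remains open.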